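Replacing an iodophenyl with a benzothiazolyl on the triazole

The source may report more compounds than this note shows. Statements on the series, on what has been measured and on what is new or still open speak of the compounds shown alone.

Compound 2 `COc1ccccc1-n1cc(COc2c(/C=C\C(=O)O)ccc(OC)c2CC=C(C)C)nn1` gives 43000 nM in a functional assay on A549 cells (Homo sapiens) for cytotoxicity, read by MTT assay, with a stated time of 24 h; on this read-out higher numbers stand for weaker inhibition and lower numbers for stronger inhibition.
Compound 3 `COc1ccc(/C=C\C(=O)O)c(OCc2cn(-c3ccccc3I)nn2)c1CC=C(C)C` gives 2200 nM in this assay.
Compound 1 `COc1ccc(/C=C\C(=O)O)c(OCc2cn(-c3ccc(NC(C)=O)cc3)nn2)c1CC=C(C)C` has "not determined" (no result reported) in this assay.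

Compound 3 has the lower of the two numbers measured. For the measured compounds named here, the single measured step is a 20-fold lower number from compound 2 to compound 3 (1.29 log units; beyond the scatter), a large one. Compound 4 `COc1ccc(/C=C\C(=O)O)c(OCc2cn(-c3nc4ccccc4s3)nn2)c1CC=C(C)C` differs from compound 3 by 1,3-benzothiazol-2-yl in place of 2-iodophenyl on an aromatic nitrogen. Going by the values given here, no measured compound carries a benzothiazolyl group on that aromatic nitrogen, so the measured step offers no direct guide to this change, and a shift in either direction is possible. With that uncertainty, compound 4 is expected to give 5000 nM (range 1000 nM to 30000 nM), which would mean a 2.3-fold higher number from compound 3 to compound 4 (0.36 log units; beyond the scatter).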

Compound 4, half-maximal inhibitory concentration: 42100 nM
The estimate for compound 4 lay 8.4-fold (0.93 log units) below the measured number; measured number above the stated range.
By their numbers in this assay, from the lowest: compound 3; then compounds 4 and 2 (each within the scatter of the next).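

In this assay, 1,3-benzothiazol-2-yl in place of 2-iodophenyl on this aromatic nitrogen gives a 19-fold higher number from compound 3 to compound 4 (1.28 log units; beyond the scatter) and removes the advantage that the iodo compound held. In place of 2-methoxyphenyl the same group gives a 1.0-fold lower number from compound 2 to compound 4 (0.01 log units; within the scatter) and leaves the number effectively unchanged, so among the measured compounds only compound 3 stands apart. Nothing available explains this difference. From the compounds shown here alone, whether the iodine itself is what matters stays open. A chlorine or an amine in its place on the phenyl ring could test this.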